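The source may hold more compounds than are shown below. What is called first, only, known or untested is meant among the compounds shown, and "the series" means these compounds.

Compound 1 `CCC1=C(O)c2c(oc(-c3cc(C)c(C)cc3C)cc2=O)C(CC)(CC)C1=O` gives 8.2 uM
Compound 2 `CCC1=C(O)c2c(oc(-c3ccc(OC)c(Cl)c3)cc2=O)C(CC)(CC)C1=O` gives 24.9 uM

Going by the values given here, in a functional assay on KB cells (Homo sapiens) for antiproliferative activity, read by sulforhodamine B assay, with a stated time of 3 days (on this read-out higher numbers stand for an effect only at larger amounts of compound and lower numbers for an effect already at smaller amounts), compound 1 holds the lower of the two numbers so far. Compound 3 `CCC1=C(O)c2c(oc(-c3cc(C)c(OC)cc3C)cc2=O)C(CC)(CC)C1=O` differs from compound 1 by a single change, methoxy in place of methyl on an aromatic carbon, para to a large group (methoxy in place of methyl on an aromatic carbon). Among the compounds with values here, the one measured step (a 3.0-fold higher number from compound 1 to compound 2 (0.48 log units; beyond the scatter)) also brings in a methoxy group, but alongside other changes to that ring, so it is only a loose guide, and it was modest. A small rise in the number, perhaps none beyond the scatter, is therefore expected (a 1.5-fold higher number from compound 1 to compound 3 (0.17 log units; within the scatter)). The estimated value for compound 3 is 12 uM (expected range 5 uM to 28 uM).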

Compound 3, concentration for half-maximal effect: 36.6 uM
Compound 3: middle estimate off by 3.1-fold (0.48 log units), on the low side; the whole stated range lies below it.
By their numbers in this assay, from the lowest: compound 1; then compounds 2 and 3 (each within the scatter of the next).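

Replacing the methyl para to a large group with methoxy gives a 4.5-fold higher number from compound 1 to compound 3 (0.65 log units; beyond the scatter), so more compound is needed for the same effect. Compound 2 differs from compound 1 at several places on that ring, whereas this step isolates a single group and shows that this position alone responds to the change. Nothing measured here bears on the reason for this rise. Still open, going by these compounds, is how other groups at this position would behave, such as a hydroxyl, an amine or an ethyl chain. Also open, on these data alone, is whether methoxy would bring a similar rise at the other methyl positions.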